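A Fluoro Swap on a Weakly Inhibiting Compound

The source may report more compounds than this note shows. Statements on the series, on what has been measured and on what is new or still open speak of the compounds shown alone.

Compound 1 `CCOC(=O)C1=CCCCC1S(=O)(=O)Nc1ccc(Cl)cc1`: 400 nM.
Compound 2 `CCOC(=O)C1=C(S(=O)(=O)Nc2ccccc2)CCCC1`: > 8200 nM.

Both values come from a functional assay on RAW264.7 cells (Mus musculus) for inhibition; on this read-out lower numbers stand for stronger inhibition and higher numbers for weaker inhibition. Compound 1 gives a real number there, 400 nM. Compound 2 gives no exact number, only > 8200 nM, and that value is a limit of the assay.

Compound 3 `CCOC(=O)C1=C(S(=O)(=O)Nc2ccc(F)cc2)CCCC1` keeps the core of compound 2 and changes it in one place, with fluoro in place of hydrogen on an aromatic carbon, turning phenyl into 4-fluorophenyl: fluoro in place of hydrogen on an aromatic carbon.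

Within the data shown here, no measured pair shows what this single change does. Compound 2 sits at the limit > 8200 nM, so the expectation in this assay is no step beyond the scatter, in either direction. The expected step is a step that the limit leaves unreadable from compound 2 to compound 3. The estimate for compound 3 is 9000 nM, with an expected range from 3500 nM to 25000 nM.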

Compound 3, half-maximal inhibitory concentration: 1400 nM
Beside the measured number, compound 3's estimate is 6.4-fold (0.81 log units) above it, and the stated range ends above it.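

In this assay, turning phenyl into 4-fluorophenyl gives an at least 5.8-fold lower number from compound 2 to compound 3 (0.76 log units; beyond the scatter), so this place on the ring is not indifferent: one fluorine atom in place of a hydrogen is enough to give a measurable number. Compound 2 has only a limit, > 8200 nM, and not an exact number. The true size of the step therefore cannot be read, only its smallest possible size, because the starting point is a limit: the limit of > 8200 nM in this assay, at which 1 of the 3 values shown sits.

The compounds shown leave open whether this gain is particular to fluoro, or whether a methyl, a methoxy or an amine at the same place on the shared core would give a similar step. They also leave open how fluoro would read on another carbon of the same ring.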